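The compounds below may be only part of what the source reports. "The series", "measured", "known", "first", "only" and "open" are said of these compounds alone.

Measured so far:
compound 1 `Cc1ccc(N2CCn3c2n[nH]c(=O)c3=N)cc1`; in a functional assay on A549 cells (Homo sapiens) for antiproliferative activity, with a stated time of 72 h, tested at 50 ug/mL (a lower number here means a weaker effect, a higher number a stronger effect of the compound at the concentration tested), compound 1 gives 38%.
compound 2 `N=c1c(=O)[nH]nc2n1CCN2c1ccccc1`; in this assay compound 2 gives 38%.

Compound 2 stands level with compound 1 in this assay. Within the data shown here, the one measured step, no change at the digits printed from compound 1 to compound 2 (within the scatter), hydrogen in place of methyl on an aromatic carbon, lay within the scatter. Compound 3 `N=c1c(=O)[nH]nc2n1CCN2c1ccc(Cl)cc1` differs from compound 2 by chloro in place of hydrogen on an aromatic carbon. That earlier exchange of a small group on an aromatic carbon left the read-out unchanged, so no movement beyond the scatter is expected here either, and the step of a number 2 percentage points higher from compound 2 to compound 3 (within the scatter) is estimated to be small. Compound 3 is therefore expected to give about 40%, within 20% to 60%.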

Compound 3, a percentage reported as inhibition, at one concentration (the size of the read-out at that concentration, not a potency): 27%
Estimate against measurement, compound 3: 13 percentage points above, within the range that was stated.
By their numbers in this assay, from the lowest: compound 3; then compounds 1 and 2 (each within the scatter of the next).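

At this aromatic carbon, para to a large group, the choice of group can move the read-out: in this assay chloro in place of hydrogen gives a number 11 percentage points lower from compound 2 to compound 3 (beyond the scatter), which the exchange of methyl and hydrogen did not show. Chloro in place of methyl gives a number 11 percentage points lower from compound 1 to compound 3 (beyond the scatter), so chloro stands apart from both of the other groups at this position. No measurement shown explains this drop. The compounds shown leave open how an amine, a methoxy group or a carboxylic acid would read at this position. As far as these compounds go, whether any group here would raise the number also stays open.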